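This account rests on a few compounds, and the source may have more. Where it says the series, first, only, none or still open, it means among the compounds named here.

Compound 1 `CCN1CCN(CCCn2cnc3c(N4CCN(CC)CC4)ncnc32)CC1` gives 1190 nM in an assay on HEK293 cells for antagonist activity at Toll-like receptor 9 (Homo sapiens), read by spectrophotometry; on this read-out lower numbers stand for stronger inhibition and higher numbers for weaker inhibition. Compound 2 `CCN1CCN(CCCn2cnc3c(N4CCN(CC)CC4)nc(NC(=O)c4ccccc4)nc32)CC1` gives 340 nM in this assay, and a 3.5-fold lower number from compound 1 to compound 2 (0.54 log units; beyond the scatter). On these two numbers compound 2 stands lowest, with compound 1 as its only comparator. Compound 3 `CCN1CCN(CCCn2cnc3c(N4CCN(CC)CC4)nc(N4CCCC4)nc32)CC1` is not yet measured; it differs from compound 2 by pyrrolidin-1-yl in place of benzamido on an aromatic carbon. Among the compounds with values here, the only measured step that bears on this position is a 3.5-fold lower number from compound 1 to compound 2 (0.54 log units; beyond the scatter), which showed benzamido in place of hydrogen lowering the number. Within the data shown here, no measured step shows what a group of fewer heavy atoms and no hydrogen-bond donor does at the same carbon. The expectation for compound 3 is therefore a number lying between those of compound 1 and compound 2, a 2.1-fold higher number from compound 2 to compound 3 (0.31 log units; beyond the scatter), rising from compound 2 since the loss of the benzamido removes the group behind a 3.5-fold lower number from compound 1 to compound 2 (0.54 log units; beyond the scatter). Compound 3 is estimated at 700 nM, with a range of 250 nM to 2000 nM.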

Compound 3, half-maximal inhibitory concentration: 500 nM
The estimate for compound 3 lay 1.4-fold (0.15 log units) above the measured number; the measured number falls inside the stated range.
By their numbers in this assay, from the lowest: compounds 2 and 3 (each within the scatter of the next); then compound 1.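

In this assay, the carbon between two ring nitrogen atoms accepts more than one kind of group: pyrrolidin-1-yl in place of hydrogen gives a 2.4-fold lower number from compound 1 to compound 3 (0.38 log units; beyond the scatter), so the shift from compound 1 is not unique to benzamido. Exchanging benzamido for pyrrolidin-1-yl gives a 1.5-fold higher number from compound 2 to compound 3 (0.17 log units; within the scatter), so compounds 2 and 3 cannot be told apart, and neither the carbon-only aromatic ring, the carbonyl nor the amide hydrogen of benzamido is required for a number beyond the scatter from compound 1. No measurement on hand explains this result.

Open, on these data alone, is whether a plain amino group or a methoxy group at this carbon would stay with compounds 2 and 3 or fall back towards compound 1. Also open, as far as these compounds go, is how a morpholin-4-yl ring or an acetamido group would read here.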